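The source may hold more compounds than are shown below. What is called first, only, known or untested is meant among the compounds shown, and "the series" means these compounds.

Compound 1 `CC(=O)c1ncc([C@@H](O)[C@H](O)[C@H](O)CO)s1`: 11.7 mL/min/kg
Compound 2 `CC(=O)c1nc([C@@H](O)[C@H](O)[C@H](O)CO)c(C)[nH]1`: 7 mL/min/kg

Both values come from an in vivo ADME assay on the whole organism (strain 129/SvEvBrd x C57BL/6) for pharmacokinetics, with Mus musculus as the target, at a dose of 1 mg/kg by the intravenous route; a lower number here means slower removal, a higher number faster removal of the compound. Compound 2 stands within the usual scatter of compound 1, so the two cannot be told apart on these numbers. Compound 3 `CC(=O)c1nc([C@@H](O)[C@H](O)[C@H](O)CO)c(-c2ccccc2)[nH]1` has phenyl in place of methyl on an aromatic carbon. Among the compounds with values here, no measured pair shows the effect of such a change in this assay, so any expectation is loose. The expected move, a 2.0-fold higher number from compound 2 to compound 3 (0.30 log units; within the scatter), is a modest one towards faster removal, near the edge of the scatter. Compound 3 is estimated at 14 mL/min/kg, with an expected range of 6 mL/min/kg to 32 mL/min/kg.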

Compound 3, clearance: 23.9 mL/min/kg
Compound 3: middle estimate off by 1.7-fold (0.23 log units), on the low side; measured number inside the range.
By their numbers in this assay, from the lowest: compounds 2 and 1 (each within the scatter of the next); then compound 3.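

In this assay the move from methyl to phenyl on this aromatic carbon gives a 3.4-fold higher number from compound 2 to compound 3 (0.53 log units; beyond the scatter) and so lies beyond the scatter, a modest step. Within the data shown here, it is the first single-place change, and it shows that removal at this position responds to the group it carries, with phenyl going with faster removal than methyl. No measurement at hand accounts for the step.

Only these two groups are shown at this carbon. From the compounds shown here alone, whether an ethyl chain, a cyclohexyl ring or a pyridine ring would track with phenyl or with methyl remains open.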